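The source may report more compounds than this note shows. Statements on the series, on what has been measured and on what is new or still open speak of the compounds shown alone.

Working notes on the series in a functional assay on SF-539 cells (Homo sapiens) for inhibition, read by sulforhodamine B assay, with a stated time of 48 h; on this read-out higher numbers stand for lower toxicity in this test and lower numbers for higher toxicity in this test. Compound 1 `COc1cc(-c2nn(-c3cccc(NC(=O)c4ccc(Cl)c(C(F)(F)F)c4)c3)cc2-c2ccncc2)ccc1Cl` gives only a limit there, > 32500 nM, and so yields no number. Within the data shown here, compound 2 `O=C(Nc1cccc(-n2cc(-c3ccncc3)c(-c3ccc(Cl)c(O)c3)n2)c1)Nc1cc(C(F)(F)F)cc(C(F)(F)F)c1` gives 2890 nM in this assay, the only number in the set. The remaining entry is a limit, (the limit of > 32500 nM in this assay, at which 1 of the 2 values shown sits), which belongs to compound 1.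

Compound 3 `O=C(Nc1cccc(-n2cc(-c3ccncc3)c(-c3ccc(Cl)c(O)c3)n2)c1)Nc1cccc(C(F)(F)F)c1` differs from compound 2 by hydrogen in place of trifluoromethyl on an aromatic carbon. Among the measured compounds shown here, no measured pair covers this change, so no step is known to guide it. The expected step from compound 2 to compound 3 in this assay is a 1.2-fold higher number from compound 2 to compound 3 (0.10 log units; within the scatter), which lies within the usual scatter. Compound 3 is therefore estimated at 3600 nM, with a range from 1300 nM to 10000 nM.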

Compound 3, concentration lethal to 50% of the cells: > 32500 nM
Compound 3 was reported as a limit; the forecaster's own chance of this, stated with the estimate: 10%; middle value at least 9.0-fold (0.95 log units) away from the limit.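

In this assay, among these compounds, hydrogen in place of trifluoromethyl on an aromatic carbon gives an at least 11-fold higher number from compound 2 to compound 3 (1.05 log units; beyond the scatter), the first step that can be read. This position, meta to a trifluoromethyl group, therefore matters on this read-out, with the lower number belonging to compound 2, which carries the second trifluoromethyl. Compound 3 gives a limit and not a number, so the full size of the step stays unread: the limit of > 32500 nM in this assay, at which 2 of the 3 values shown sit.

Only hydrogen and trifluoromethyl are shown at this position. Going by these compounds, whether an amine or a carboxylic acid there would give a number on this read-out remains open.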